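The source may report more compounds than this note shows. Statements on the series, on what has been measured and on what is new or still open speak of the compounds shown alone.

Measured so far in an assay on isolated protein for inhibition of leukotriene C4 synthase (Homo sapiens), read by LC-MS, with stated times of 45 min and 20 min; on this read-out higher numbers stand for weaker inhibition and lower numbers for stronger inhibition:

compound 1, `COc1cc(N(CC2CC2)c2ccc(Cl)c(Cl)c2)cnc1C(=O)[C@H]1C[C@@H]1C(=O)O`: 27.7 nM
compound 2, `COc1cc(N(CC2CC2)c2ccccc2)cnc1C(=O)[C@H]1C[C@@H]1C(=O)O`: 1640 nM
compound 3, `COc1cc(N(CC2CC2)c2ccc(F)c3ccccc23)cnc1C(=O)[C@H]1C[C@@H]1C(=O)O`: 26.5 nM

Compound 3 and compound 1 give numbers that sit within the scatter of each other in this assay, so neither can be called the stronger inhibitor; compound 2 stands far higher than both. Among the measured compounds shown here, the one step that can be read between these compounds is a 59-fold higher number from compound 1 to compound 2 (1.77 log units; beyond the scatter), a change of the aromatic group that hangs on the nitrogen, and it was large.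

Compound 4, `CCCN(c1cnc(C(=O)[C@H]2C[C@@H]2C(=O)O)c(OC)c1)c1ccc(F)c2ccccc12`, differs from compound 3 in a different place: ethyl in place of cyclopropyl on a saturated chain carbon bound to a nitrogen on an aromatic ring. For the measured compounds named here, no measured step touches this chain on the nitrogen, so the one known step gives no direct guide. The change is small in size and leaves the rest of compound 3 untouched, and the expectation is therefore a step of no more than the usual scatter in this assay, in either direction. Compound 4 is expected to give about 40 nM, within a range of 15 nM to 110 nM, which means an estimated 1.5-fold higher number from compound 3 to compound 4 (0.18 log units; within the scatter).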

Compound 4, half-maximal inhibitory concentration: 7.09 nM
Beside the measured number, compound 4's estimate is 5.6-fold (0.75 log units) above it; measured number outside the range, below it.
By their numbers in this assay, from the lowest: compound 4; then compounds 3 and 1 (each within the scatter of the next); then compound 2.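

The chain on the nitrogen is not a silent place: in this assay, ethyl in place of cyclopropyl on a saturated chain carbon bound to a nitrogen on an aromatic ring gives a 3.7-fold lower number from compound 3 to compound 4 (0.57 log units; beyond the scatter). Among the compounds shown here, the only earlier step concerned the aromatic group on that nitrogen, so this is the first sign that the other group there also matters, though this step is modest in size. Read one bond further out, the change is cyclopropylmethyl to propyl, and no measurement at hand explains why the number falls.

As far as these compounds go, whether a longer chain such as butyl, or a chain ending in an amine, would shift the number further remains open. Also open, from the compounds shown here alone, is whether the same change would act alike with the 3,4-dichlorophenyl group of compound 1 on the nitrogen.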